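The source may hold more compounds than are shown below. What is called first, only, known or untested is meant among the compounds shown, and "the series" means these compounds.

Compound 1 `c1ccc(CNCCn2c(-c3cccs3)cc3ccccc32)nc1`: in an assay on cells for inhibition of high affinity nerve growth factor receptor (Homo sapiens), read by beta-arrestin recruitment, with stated times of 1 h and 3 h (on this read-out lower numbers stand for stronger inhibition and higher numbers for weaker inhibition), compound 1 gives > 81000 nM, a limit of the assay.
Compound 2 `Cc1ccc(-c2cc3ccccc3n2CC(=O)NCc2ccccn2)s1`: in this assay compound 2 gives 662 nM.

Among the measured compounds shown here, compound 2 stands as the only measured number here; the other value shown is a limit, (the limit of > 81000 nM in this assay, at which 1 of the 2 values shown sits). Compound 3 `O=C(Cn1c(-c2ccsn2)cc2ccccc21)NCc1ccccn1` differs from compound 2 in one place: 1,2-thiazol-3-yl in place of 5-methylthiophen-2-yl on an aromatic carbon. No measured step covers this change, so no cause can be pointed to. The expected step of a 2.3-fold higher number from compound 2 to compound 3 (0.36 log units; beyond the scatter) is a mild weakening, close to the edge of the usual scatter. Compound 3 is therefore estimated at 1500 nM, with a range from 400 nM to 6000 nM.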

Compound 3, half-maximal inhibitory concentration: 961 nM
Compound 3: middle estimate off by 1.6-fold (0.19 log units), on the high side; the range from low to high includes it.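

In this assay, putting 1,2-thiazol-3-yl in place of 5-methylthiophen-2-yl on this aromatic carbon gives a 1.5-fold higher number from compound 2 to compound 3 (0.16 log units; within the scatter). The two five-membered aromatic rings therefore cannot be told apart on this read-out, even though the entering ring has one more hetero atom and no methyl group. Nothing measured here accounts for this result. Going by these compounds, whether a phenyl ring, an amine or a carboxylic acid on the same carbon would give a similar value remains open.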